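The source may hold more compounds than are shown below. What is called first, only, known or untested is meant among the compounds shown, and "the series" means these compounds.

Measured so far in an assay on HEK cells for antagonist activity at transient receptor potential cation channel subfamily V member 1 (Homo sapiens), read by FLIPR; on this read-out lower numbers stand for stronger inhibition and higher numbers for weaker inhibition:
compound 1, `CCCCCCOc1nc(C(F)(F)F)ccc1CNC(=O)Nc1cccc2[nH]c(=O)ccc12`: 3.19 nM
compound 2, `CC(C)COc1nc(C(F)(F)F)ccc1CNC(=O)Nc1cccc2[nH]c(=O)ccc12`: 2.6 nM

Compound 2 gives the lower of the two numbers in this assay, yet its gap to compound 1 is within the scatter, so the two cannot be ordered. For the measured compounds named here, the only measured step, a 1.2-fold lower number from compound 1 to compound 2 (0.09 log units; within the scatter), changes the chain on the oxygen attached to the aromatic carbon and leaves the number essentially unchanged.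

Compound 3, `O=C(NCc1ccc(C(F)(F)F)nc1SC1CCCCC1)Nc1cccc2[nH]c(=O)ccc12`, is not yet measured. It differs from compound 2 by cyclohexylsulfanyl in place of isobutoxy on an aromatic carbon. Going by the values given here, the one measured step concerns the same position and bears on this change only in part: it shows that altering the saturated chain there moves nothing beyond the scatter, but no measured pair exchanges the oxygen for sulfur or puts a ring at this position. On that basis a small step is expected, a 1.9-fold higher number from compound 2 to compound 3 (0.28 log units; within the scatter), with a wide range. Compound 3 is expected to give about 5 nM, between 1.5 nM and 20 nM.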

Compound 3, half-maximal inhibitory concentration: 2.15 nM
For compound 3 the middle estimate is 2.3-fold (0.37 log units) above the measured one, within the range that was stated.
By their numbers in this assay, from the lowest: compounds 3, 2 and 1 (each within the scatter of the next).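

In this assay, the aromatic carbon next to the ring nitrogen now takes a sulfur link and a six-membered non-aromatic ring in place of an oxygen link and an open chain, with the number staying within the scatter (a 1.2-fold lower number from compound 2 to compound 3 (0.08 log units; within the scatter)). The same holds against the hexyloxy compound (a 1.5-fold lower number from compound 1 to compound 3 (0.17 log units; within the scatter)), so all three groups seen here, open-chain or cyclic, give numbers that cannot be ordered. No data on any other property bear on this result.

The sulfur and the ring enter together, so the compounds shown leave open what each contributes alone, as a cyclohexyloxy or an open-chain alkylsulfanyl group would show. They also leave open whether this position would accept an amine or a carboxylic acid, or whether a much shorter chain such as methoxy would keep the number in this range.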